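Replacing a phenol-bearing benzyl group: expected solubility of compound 4

The compounds below may be only part of what the source reports. "The series", "measured", "known", "first", "only" and "open" are said of these compounds alone.

Measured so far:
- compound 1 `COc1ccc(-c2ccc3c(NCCCNCc4cccc(OC)c4O)ccnc3c2)cc1`: 32000 nM
- compound 2 `COc1cccc(CNCCCNc2ccnc3cc(Cc4cc(C)cc(C)c4)ccc23)c1O`: 4200 nM
- compound 3 `COc1cccc(CNCCCNc2ccnc3cc(Oc4cccc(N(C)C)c4)ccc23)c1O`: 14500 nM

In a physicochemical assay for solubility, with a stated time of 18 h, at pH 7.4 (on this read-out higher numbers stand for higher solubility and lower numbers for lower solubility), compound 1 stands highest of the three; compound 3 comes nearest, by a 2.2-fold lower number from compound 1 to compound 3 (0.34 log units; beyond the scatter), and compound 2 lies furthest, by a 7.6-fold lower number from compound 1 to compound 2 (0.88 log units; beyond the scatter). Compound 4 `COc1ccc(-c2ccc3c(NCCCNCc4cc(F)ccc4OC)ccnc3c2)cc1` differs from compound 1 in this way: 5-fluoro-2-methoxyphenyl in place of 2-hydroxy-3-methoxyphenyl on a saturated chain carbon bound to an amine nitrogen. The measured steps, a 7.6-fold lower number from compound 1 to compound 2 (0.88 log units; beyond the scatter), a 2.2-fold lower number from compound 1 to compound 3 (0.34 log units; beyond the scatter) and a 3.5-fold higher number from compound 2 to compound 3 (0.54 log units; beyond the scatter), all change the group on an aromatic carbon of the shared core, not the part altered here, so none bears directly on this change. With no direct guide, a modest fall is expected, a 2.1-fold lower number from compound 1 to compound 4 (0.33 log units; beyond the scatter), giving an estimated 15000 nM for compound 4, in a range from 5000 nM to 45000 nM.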

Compound 4, solubility: 32000 nM
Compound 4: the middle estimate sits 2.1-fold (0.33 log units) below what was measured, and the stated range covers the measured number.
By their numbers in this assay, from the lowest: compound 2; then compound 3; then compounds 1 and 4 (each within the scatter of the next).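

In this assay, 5-fluoro-2-methoxyphenyl in place of 2-hydroxy-3-methoxyphenyl on a saturated chain carbon bound to an amine nitrogen gives no change at the digits printed from compound 1 to compound 4 (within the scatter). Among these compounds, the group that leaves has a hydrogen-bond donor and the one that enters has none, yet this step stays within the scatter, unlike the earlier steps on an aromatic carbon of the shared core. No supporting measurement is available to explain this result. The compounds shown leave open what the fluorine and the loss of the hydroxyl each do alone, and how a carboxylic acid or an amine on this group would read.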